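Swapping an aryl halide for a methylsulfanyl on the urea

The source may report more compounds than this note shows. Statements on the series, on what has been measured and on what is new or still open speak of the compounds shown alone.

The series shares a core seen in compound 1 `O=C(Nc1ccccc1F)N[C@H]1CC[C@H](Oc2ccc(F)cc2)CC1`, which in a functional assay on CRL2813 cells (Homo sapiens) for cytotoxicity, read by sulforhodamine B assay, with a stated time of 5 days (a lower number here means a stronger inhibitor, a higher number a weaker inhibitor), gives 17500 nM. Compound 2 `O=C(Nc1cccc(Br)c1)N[C@H]1CC[C@H](Oc2ccc(F)cc2)CC1` gives 6200 nM, and compound 3 `O=C(Nc1cccc(I)c1)N[C@H]1CC[C@H](Oc2ccc(F)cc2)CC1` gives 5200 nM. Compound 3 and compound 2 stand together with lower numbers than compound 1, as shown by the steps of a 3.4-fold lower number from compound 1 to compound 3 (0.53 log units; beyond the scatter) and a 2.8-fold lower number from compound 1 to compound 2 (0.45 log units; beyond the scatter), while a 1.2-fold lower number from compound 2 to compound 3 (0.08 log units; within the scatter). Compound 4 `CSc1ccc(NC(=O)N[C@H]2CC[C@H](Oc3ccc(F)cc3)CC2)cc1` differs from compound 3 by 4-(methylsulfanyl)phenyl in place of 3-iodophenyl on an amide-type nitrogen. Within the data shown here, no measured step exchanges a halogen for a methylsulfanyl group, nor moves a group around the ring on this nitrogen. Among the measured compounds shown here, the only bearing steps show that a halogen at the 3-position of the phenyl gave a modest gain over compound 1, and that iodo against bromo made no difference beyond the scatter. With nothing closer to rest on, compound 4 is expected to show a 1.5-fold higher number from compound 3 to compound 4 (0.19 log units; within the scatter), most likely a small loss. Compound 4 is therefore estimated at 8000 nM, within 3500 nM to 20000 nM.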

Compound 4, half-maximal inhibitory concentration: > 20000 nM
Compound 4: no number, only a limit; the forecaster's own chance of this, stated with the estimate: 5%; middle value at least 2.5-fold (0.39 log units) away from the limit.
By their numbers in this assay, from the lowest: compounds 3 and 2 (each within the scatter of the next); then compound 1. At a limit, above all of these: compound 4.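

In this assay, among these compounds, compound 4 gives > 20000 nM, which is a limit of the assay and not a number, and no other compound shown sits there: the limit of > 20000 nM in this assay, at which 1 of the 4 values shown sits. The aryl group on this amide-type nitrogen therefore matters more than the exchange of iodo for bromo suggested, since 4-(methylsulfanyl)phenyl gives an at least 3.8-fold higher number from compound 3 to compound 4 (0.58 log units; beyond the scatter) and an at least 3.2-fold higher number from compound 2 to compound 4 (0.50 log units; beyond the scatter). The gain seen with the two halogens does not carry over to this group, though the comparison with the weakest measured compound gives only an at least 1.1-fold higher number from compound 1 to compound 4 (0.05 log units; that floor lies within the scatter), so the order of that pair stays unsettled.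

The change alters both the group and its place on the ring, and the compounds shown cannot separate these two. As far as these compounds go, how a methoxy, an amine or a carboxylic acid on this phenyl would behave also stays open.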